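This account rests on a few compounds, and the source may have more. Where it says the series, first, only, none or still open, it means among the compounds named here.

Measured so far in an assay on cells for inhibition of MAP kinase-interacting serine/threonine-protein kinase 1 (Homo sapiens), read by mobility shift assay, with stated times of 10 min and 60 min, in the presence of a further agent that is not named here; a higher number here means a weaker inhibitor, a lower number a stronger inhibitor:
compound 1 `CC(C)Oc1cc(-c2cncc(-c3c[nH]nc3C3CC3)c2)ccc1C(N)=O`: 130 nM
compound 2 `COc1cc(-c2cccnc2)ccc1C(N)=O`: 2800 nM

Compound 1 holds the lowest of the two numbers in this assay; the nearest is compound 2, whose number is beyond the scatter higher. Going by the values given here, no step between these two has been computed, so only their two values are known.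

Compound 3 `Cc1c(-c2cncc(-c3ccc(C(N)=O)c(OC(C)C)c3)c2)cnn1C` is not yet measured. It differs from compound 1 in one place: 1,5-dimethyl-1H-pyrazol-4-yl in place of 3-cyclopropyl-1H-pyrazol-4-yl on an aromatic carbon. No comparable change has been measured in the series, so the size of the step rests on no data. A moderate rise, beyond the scatter, is expected, a 3.1-fold higher number from compound 1 to compound 3 (0.49 log units; beyond the scatter). Compound 3 is estimated in this assay at 400 nM, within 130 nM to 1300 nM.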

Compound 3, half-maximal inhibitory concentration: 60 nM
The estimate for compound 3 lay 6.7-fold (0.82 log units) above the measured number, and the stated range ends above it.
By their numbers in this assay, from the lowest: compound 3; then compound 1; then compound 2.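

In this assay 1,5-dimethyl-1H-pyrazol-4-yl in place of 3-cyclopropyl-1H-pyrazol-4-yl gives a 2.2-fold lower number from compound 1 to compound 3 (0.34 log units; beyond the scatter) as a modest step. In this pair, the position keeps its activity without the three-membered ring and without the hydrogen-bond donor of the leaving group. Nothing available accounts for the size or direction of this step.

Going by these compounds, it remains open which of the two methyl groups carries the change, since the pair replaces both ring substituents at once. Also open, on these data alone, is how a larger substituent on the pyrazole, such as an amine or a carboxylic acid, would read at this position.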